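The source may report more compounds than this note shows. Statements on the series, on what has been measured and on what is new or still open speak of the compounds shown alone.

Measured in an ADME assay on C8166 cells (Homo sapiens) for cytotoxicity, read by MTT assay; on this read-out lower numbers stand for higher toxicity in this test and higher numbers for lower toxicity in this test:

- compound 1 `Cc1cc(S(N)(=O)=O)ccc1NC(=O)COc1ccc(F)cc1Oc1cc2ccccc2cc1C`: 66900 nM
- compound 2 `Cc1cc(S(N)(=O)=O)ccc1NC(=O)COc1ccc(F)cc1Oc1ccc2cc(Br)ccc2c1`: > 357000 nM, which is a limit of the assay and not a number.

Compound 2 therefore stands only at a limit, as shown by the limit of > 357000 nM in this assay, at which 1 of the 2 values shown sits; its number is not pinned down beyond that. Compound 3 `Cc1cc(S(N)(=O)=O)ccc1NC(=O)COc1ccc(F)cc1Oc1ccc2ccccc2c1C` differs from compound 2 in one place: 1-methylnaphthalen-2-yl in place of 6-bromonaphthalen-2-yl on an oxygen on an aromatic ring. Among the measured compounds shown here, one measured step bears on this change. The step of an at least 5.3-fold higher number from compound 1 to compound 2 (0.72 log units; beyond the scatter) exchanged a methylnaphthalen-2-yl group for the 6-bromonaphthalen-2-yl group and moved the number up past the limit. Compound 3 carries a methylnaphthalen-2-yl group again, so the change from compound 2 to compound 3 runs that step largely in reverse, and a lower number in this assay is expected, of at least modest size, though the limit on compound 2 leaves the size open. The number for compound 3 is accordingly estimated at 80000 nM (range 25000 nM to 300000 nM), which is expected to mean a step of an at least 4.4-fold lower number from compound 2 to compound 3 (0.64 log units; beyond the scatter).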

Compound 3, half-maximal cytotoxic concentration: 56100 nM
Beside the measured number, compound 3's estimate is 1.4-fold (0.15 log units) above it; the measured number falls inside the stated range.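

In this assay, returning a methyl-bearing naphthalene in place of the 6-bromonaphthalen-2-yl group gives an at least 6.3-fold lower number from compound 2 to compound 3 (0.80 log units; beyond the scatter), so the effect seen from the first pair also appears with a second methylnaphthalen-2-yl group and does not rest on compound 1 alone. The two methyl-bearing groups are not separated in this test, with 1-methylnaphthalen-2-yl against 3-methylnaphthalen-2-yl giving a 1.2-fold lower number from compound 1 to compound 3 (0.08 log units; within the scatter), which is within the scatter; among the three compounds, then, only the 6-bromonaphthalen-2-yl group stands apart, and compound 2 is the one that does so. The size of that separation has only a lower bound, because compound 2 stands at a limit of the assay and not at a number: the limit of > 357000 nM in this assay, at which 1 of the 3 values shown sits.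

On these data alone, whether the separation follows the bromine itself or the place it holds on the naphthalene stays open, since the methyl and the bromine differ in both respects across these compounds. A 6-methylnaphthalen-2-yl group or a 1-bromonaphthalen-2-yl group on the same oxygen would pull these two apart, and an unsubstituted naphthalen-2-yl group would give the reference for both.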